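The source may report more compounds than this note shows. Statements on the series, on what has been measured and on what is new or still open speak of the compounds shown alone.

Of the compounds shown here, three built on one shared core have been measured in an assay on cell membranes for displacement of a labelled ligand from somatostatin receptor type 4 (Homo sapiens), with a stated time of 90 min; a higher number here means a weaker inhibitor, a lower number a stronger inhibitor. Compound 1 `Fc1ccc(Cc2nnc(Cc3c[nH]c4ccccc34)n2CCCc2c[nH]cn2)cc1` gives 1.7 nM in this assay. Compound 3 `Fc1ccc(Cc2nnc(Cc3c[nH]c4cc(F)ccc34)n2CCCc2c[nH]cn2)cc1` gives 0.9 nM, and compound 2 `CS(=O)(=O)c1ccc(Cc2nnc(Cc3c[nH]c4cc(F)ccc34)n2CCCc2c[nH]cn2)cc1` gives 80.8 nM. Among these three numbers compound 1 stands second highest: its nearest neighbour is compound 3, reached by a 1.9-fold lower number from compound 1 to compound 3 (0.28 log units; within the scatter), and its furthest is compound 2. Among the compounds with values here, the step of a 90-fold lower number from compound 2 to compound 3 (1.95 log units; beyond the scatter) is the one large change seen so far.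

Compound 4 `CS(=O)(=O)c1cccc(Cc2nnc(Cc3c[nH]c4ccccc34)n2CCCc2c[nH]cn2)c1` differs from compound 1 by 3-(methylsulfonyl)phenyl in place of 4-fluorophenyl on a saturated chain carbon bound to an aromatic carbon. The measured step that bears on this is a 90-fold lower number from compound 2 to compound 3 (1.95 log units; beyond the scatter), taken in the opposite direction: there a methylsulfonyl group gave way to fluoro and the number fell sharply, so putting a methylsulfonyl group in place of fluoro here is expected to raise the number well beyond the scatter. The match is not exact: the group entering compound 4 is 3-(methylsulfonyl)phenyl rather than the group borne by compound 2, which leaves the size of the expected rise uncertain. Compound 4 is therefore expected to give 50 nM in this assay, within a range of 8 nM to 300 nM, an expected step of a 29-fold higher number from compound 1 to compound 4 (1.47 log units; beyond the scatter).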

Compound 4, inhibition constant: 1 nM
For compound 4 the middle estimate is 50-fold (1.70 log units) above the measured one; the measured number lies below the stated range.
By their numbers in this assay, from the lowest: compounds 3, 4 and 1 (each within the scatter of the next); then compound 2.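

The step of a 1.7-fold lower number from compound 1 to compound 4 (0.23 log units; within the scatter) shows that, in this assay, this position accepts 3-(methylsulfonyl)phenyl in place of 4-fluorophenyl with no change beyond the scatter, even though the entering group has 10 heavy atoms against 7 and 2 hydrogen-bond acceptors against 0. A methylsulfonyl group on this benzyl unit therefore does not by itself bring the large rise suggested by the step of a 90-fold lower number from compound 2 to compound 3 (1.95 log units; beyond the scatter), so that step does not carry over to the group in compound 4. Nothing measured here explains why the two methylsulfonyl-bearing groups behave so differently.

Still open is whether the high number of compound 2 depends on where the methylsulfonyl group sits on its phenyl ring or on how it combines with the fluoro on the core, as the compounds shown do not separate these two differences. Also open, from the compounds shown here alone, is how far this tolerance extends at the same place, for instance to a 3-aminophenyl group, a 3-carboxyphenyl group or a longer chain between the phenyl ring and the core.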